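A few compounds are considered here, and "the series" means these few. Any claim that something is new, unique, unknown or untested is made for them only; others in the source may bear on it.

Measured compounds:
- compound 1, `CCOc1ccccc1-c1nc2cc([N+](=O)[O-])ccc2[nH]1`: 84.8%
- compound 2, `FC(F)(F)c1ccc2[nH]c(-c3ccccc3)nc2c1`: 91.2%
- compound 3, `Oc1ccc(-c2nc3cc(C(F)(F)F)ccc3[nH]2)cc1`: 51.2%

In a functional assay on aorta (Rattus norvegicus, strain Wistar) for inhibition, with a stated time of 60 min (on this read-out higher numbers stand for larger maximal responses and lower numbers for smaller maximal responses), compound 2 gives the highest of the three numbers; compound 1 lies nearest, within the scatter of it, and compound 3 lies furthest, beyond the scatter. Compound 4, `CCOc1ccccc1-c1nc2cc(C(F)(F)F)ccc2[nH]1`, has not yet been measured in this assay. It differs from compound 2 in one place, (ethoxy in place of hydrogen on an aromatic carbon), on an aromatic carbon of a six-membered aromatic ring of carbon only, ortho to a large group.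

Among the measured compounds shown here, the one step measured, a number 40 percentage points lower from compound 2 to compound 3 (beyond the scatter), puts a hydroxy on that same six-membered aromatic ring, but hydroxy and ethoxy are different groups, so it bears on the new step only loosely. Compound 1 carries the ethoxy group at the same place as compound 4 and differs from compound 2 only in the core substituent; in this assay compound 1 gives 84.8%, within the scatter of compound 2. On that ground compound 4 is expected to stay near compound 2, with a step of a number 6.2 percentage points lower from compound 2 to compound 4 (within the scatter) that is not expected to lie beyond the scatter. Compound 4 is therefore estimated at 85%, in the range 65% to 100%.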

Compound 4, largest response reached (Emax), in percent of the reference or control that the assay uses: 91%
Estimate against measurement, compound 4: 6 percentage points below; the measured number falls inside the stated range.
By their numbers in this assay, from the lowest: compound 3; then compounds 1, 4 and 2 (each within the scatter of the next).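

In this assay, ethoxy in place of hydrogen on an aromatic carbon, ortho to a large group, can now be read directly as a single step: a number 0.2 percentage points lower from compound 2 to compound 4 (within the scatter), so the hydrogen and the ethoxy group cannot be told apart at this position on this read-out. Among the compounds shown here, with ethoxy held in place, the second pair isolates the substituent on the core: trifluoromethyl in place of nitro on an aromatic carbon gives a number 6.2 percentage points higher from compound 1 to compound 4 (within the scatter), so this exchange cannot be told apart from the scatter either, and the earlier compounds offered no pair to show this. Nothing at hand bears on why either step falls within the scatter.

Going by these compounds, the step to the hydroxy compound, a number 40 percentage points lower from compound 2 to compound 3 (beyond the scatter), remains the only one here beyond the scatter, and it is open whether a hydroxy group at the position of the ethoxy group would follow that step or stay with compound 4 and compound 2. For the compounds shown here, also open is how this position would take a longer chain such as butoxy, an amine or a carboxylic acid, since ethoxy is the only group other than hydrogen seen there with the trifluoromethyl substituent on the core.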